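The source may report more compounds than this note shows. Statements on the series, on what has been measured and on what is new or still open speak of the compounds shown alone.

Measured compounds:
compound 1, `COc1ccc(-c2cc(/C=C/C(=O)c3ccc(N)cc3)[nH]n2)cc1OC`, -91%
compound 2, `COc1ccc(C(=O)/C=C/c2cc(-c3cc(OC)c(OC)c(OC)c3)n[nH]2)cc1`, -82%
compound 3, `COc1cc(C(=O)/C=C/c2cc(-c3cc(OC)c(OC)c(OC)c3)n[nH]2)cc(OC)c1OC`, -89%

In a functional assay on HCC 2998 cells (Homo sapiens) for cytotoxicity, read by sulforhodamine B assay, with a stated time of 48 h, tested at 100 uM (on this read-out lower numbers stand for a stronger effect and higher numbers for a weaker effect at the one concentration tested), compound 2 gives -82%, the highest of the three numbers. Compound 3 gives -89%, and compound 1 gives -91%; both of these differ from compound 2 by amounts within the usual scatter, so the three numbers are read as alike, all marking a strong effect at the one concentration tested.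

Compound 4, `COc1cc(-c2cc(/C=C/C(=O)c3ccc(F)c(F)c3)[nH]n2)cc(OC)c1OC`, has not yet been measured. It differs from compound 2 in one place: 3,4-difluorophenyl in place of 4-methoxyphenyl on a carbonyl carbon. Among the measured compounds shown here, no step between measured compounds shows what such a change does, so the expectation rests only on the three numbers above, which all lie close together.

Compound 4 is expected to give an estimate of -80% in this assay, with a range from -100% to -45%. The step from compound 2 to compound 4 is therefore expected to be a number 2 percentage points higher from compound 2 to compound 4 (within the scatter), a change not clearly beyond the scatter, leaning if anything toward a weaker effect.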

Compound 4, a percentage reported as activity, at one concentration (the size of the read-out at that concentration, not a potency): -11%
Compound 4: middle estimate off by 69 percentage points, on the low side; measured number above the stated range.
By their numbers in this assay, from the lowest: compounds 1, 3 and 2 (each within the scatter of the next); then compound 4.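

In this assay, among the compounds shown here, the step of a number 71 percentage points higher from compound 2 to compound 4 (beyond the scatter) shows that the group on this carbonyl carbon is far from indifferent, which the three earlier numbers, lying close together and linked by no single-place step, could not reveal. For the compounds shown here, the change keeps the count of heavy atoms and the single aromatic ring, yet 3,4-difluorophenyl in place of 4-methoxyphenyl gives a much weaker effect at the one concentration tested, and the hydrogen-bond acceptor counted on the leaving group has no counterpart on the entering one. Nothing shown here gives a measured reason for this step.

The compounds shown leave open whether the step follows from the loss of the methoxy group or from the entry of the two fluorines. A plain phenyl or a 4-hydroxyphenyl on the same carbonyl carbon would bear on that question.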